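Methoxy on the phenyl group of compound 3

The compounds below may be only part of what the source reports. "The series", "measured", "known", "first", "only" and "open" are said of these compounds alone.

Measured in a functional assay on A549 cells (Homo sapiens) for cytotoxicity (on this read-out lower numbers stand for stronger inhibition and higher numbers for weaker inhibition), so far
- compound 1 `C=C/C=C\[C@H](C)[C@H](OC(N)=O)[C@@H](C)[C@H](O)[C@@H](C)C/C(C)=C\[C@H](C)[C@@H](O)[C@@H](C)/C=C\CCc1cccc(F)c1` gives 650 nM
- compound 2 `C=C/C=C\[C@H](C)[C@H](OC(N)=O)[C@@H](C)[C@H](O)[C@@H](C)C/C(C)=C\[C@H](C)[C@@H](O)[C@@H](C)/C=C\CCc1sccc1C` gives 790 nM
- compound 3 `C=C/C=C\[C@H](C)[C@H](OC(N)=O)[C@@H](C)[C@H](O)[C@@H](C)C/C(C)=C\[C@H](C)[C@@H](O)[C@@H](C)/C=C\CCc1ccccc1` gives 510 nM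

The three values are not separated, and compound 3 stands within the scatter of both other compounds. Compound 4 `C=C/C=C\[C@H](C)[C@H](OC(N)=O)[C@@H](C)[C@H](O)[C@@H](C)C/C(C)=C\[C@H](C)[C@@H](O)[C@@H](C)/C=C\CCc1cccc(OC)c1` is the next to read, with methoxy in place of hydrogen on an aromatic carbon as its difference: methoxy in place of hydrogen on an aromatic carbon, meta to a large group. The closest measured change is hydrogen in place of fluoro on an aromatic carbon, which gave a 1.3-fold lower number from compound 1 to compound 3 (0.11 log units; within the scatter) in a 3-fluorophenyl compound. Phenyl in place of 3-methylthiophen-2-yl gave a 1.5-fold lower number from compound 2 to compound 3 (0.19 log units; within the scatter) as well. Both steps stay within the scatter, so no step beyond the scatter is expected in this assay and no direction can be firmly called. Going by the values given here, no measured compound carries methoxy, which keeps the range wide. The expected result is a 1.2-fold higher number from compound 3 to compound 4 (0.07 log units; within the scatter) and this remains inside the scatter. The estimate for compound 4 is 600 nM with 300 nM to 1200 nM as its expected range.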

Compound 4, half-maximal inhibitory concentration: 600 nM
Estimate against measurement, compound 4: no gap at the digits printed, within the range that was stated.
By their numbers in this assay, from the lowest: compounds 3, 4, 1 and 2 (each within the scatter of the next).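

In this assay methoxy on the aromatic carbon meta to a large group gives a 1.2-fold higher number from compound 3 to compound 4 (0.07 log units; within the scatter) and so adds 2 heavy atoms at this position with no step beyond the scatter. The comparisons with the other aromatic ends read the same way, with a 1.1-fold lower number from compound 1 to compound 4 (0.03 log units; within the scatter) for methoxy in place of fluoro and a 1.3-fold lower number from compound 2 to compound 4 (0.12 log units; within the scatter) for 3-methoxyphenyl in place of 3-methylthiophen-2-yl. No evidence on the cause of these results accompanies the series.

As far as these compounds go, it remains open whether an amine or a carboxylic acid at this position would also stay within the scatter of compound 3. From the compounds shown here alone, it is equally open whether a longer chain in place of the phenethyl link would leave the number within the scatter.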